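Pyrrolidinyl in place of hydroxypiperidinyl on the chain tail

A few compounds are considered here, and "the series" means these few. Any claim that something is new, unique, unknown or untested is made for them only; others in the source may bear on it.

The account follows compound 2 `Cn1ncc(Cl)c1-c1cc(C(=O)N[C@@H]2CN[C@H](CCN3CCC(O)CC3)C[C@H]2c2ccc(Cl)c(Cl)c2)oc1Cl` to compound 4 `Cn1ncc(Cl)c1-c1cc(C(=O)N[C@@H]2CN[C@H](CCN3CCCC3)C[C@H]2c2ccc(Cl)c(Cl)c2)oc1Cl`. In an assay for inhibition of RAC-alpha serine/threonine-protein kinase (Homo sapiens), read by HTRF, with a stated time of 1 h (on this read-out higher numbers stand for weaker inhibition and lower numbers for stronger inhibition), compound 2 gives 5.99 nM, the higher of the two numbers recorded for this series; compound 1 `Cn1ncc(Cl)c1-c1cc(C(=O)N[C@@H]2CN[C@H](CC(O)CO)C[C@H]2c2ccc(F)c(F)c2)oc1Cl` gives 3.31 nM, a gap that lies within the scatter. Compound 3 `O=C(N[C@@H]1CNCC[C@H]1c1ccc(Cl)cc1)c1ccc(-c2ncnc3c2CCC3O)s1` reaches only the limit > 1000 nM, which is a limit and not a number. The change from compound 2 to compound 4 is pyrrolidin-1-yl in place of 4-hydroxypiperidin-1-yl on a saturated chain carbon, two bonds along the chain from a saturated ring carbon. Among the compounds with values here, no step of this type has been measured here, so the shift is expected to stay within the scatter, with no clear direction. Compound 4 is therefore estimated at 7 nM, from 2.5 nM to 20 nM, an expected step of a 1.2-fold higher number from compound 2 to compound 4 (0.07 log units; within the scatter).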

Compound 4, half-maximal inhibitory concentration: 6.41 nM
Estimate against measurement, compound 4: 1.1-fold (0.04 log units) above; the range from low to high includes it.
By their numbers in this assay, from the lowest: compounds 1, 2 and 4 (each within the scatter of the next). At a limit, above all of these: compound 3.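

In this assay, pyrrolidin-1-yl in place of 4-hydroxypiperidin-1-yl gives a 1.1-fold higher number from compound 2 to compound 4 (0.03 log units; within the scatter). Within the data shown here, this is the first step read at this place, and it shows that, in the setting of compound 2, the tail on this saturated chain carbon can go without the hydroxyl-bearing six-membered ring with no readable change. Nothing among the data shown offers a reason for this result. From the compounds shown here alone, whether a morpholin-4-yl group, an open-chain dimethylamino group or a longer chain would hold up equally well at this place remains open.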